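A few compounds are considered here, and "the series" means these few. Any claim that something is new, unique, unknown or untested is made for them only; others in the source may bear on it.

Measured in an ADME assay on microsomes from liver (Homo sapiens) for metabolic stability, with a stated time of 10 min; a higher number here means that more of the compound is left, a lower number that less of the compound is left:

Compound 1 `O=C(O)C12CCC(C(=O)N3CC[C@](c4ccc(C(F)(C(F)(F)F)C(F)(F)F)cc4)(S(=O)(=O)c4ccc(F)cc4)C3)(CC1)C2`: "not determined" (no result reported)
Compound 2 `O=C(O)C12CCC(C(=O)N3CC[C@](c4ccc(C(F)(C(F)(F)F)C(F)(F)F)cc4)(S(=O)(=O)c4ccc(F)cc4)C3)(CC1)CC2`: 100%
Compound 3 `O=C(C1CCS(=O)(=O)C1)N1CC[C@](c2ccc(C(F)(C(F)(F)F)C(F)(F)F)cc2)(S(=O)(=O)c2ccc(F)cc2)C1`: 100%; 100% (2 entries)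

Among these three compounds, only compound 2 has a single reported number, 100%. Compound 1 has no result, and compound 3 has two entries, shown together as 100%; 100% (2 entries). Compound 2 therefore stands level with compound 3 in this assay, and nothing can be said of how it compares with compound 1.

The next compound to be tested is compound 4 `O=C(C1CCS(=O)(=O)CC1)N1CC[C@](c2ccc(C(F)(C(F)(F)F)C(F)(F)F)cc2)(S(=O)(=O)c2ccc(F)cc2)C1`. It keeps the shared core and the amide-type nitrogen in a ring, but the group on the carbonyl carbon changes: a group of 8 heavy atoms (5 carbon, 2 oxygen, 1 sulfur; one six-membered non-aromatic ring with 1 hetero atom) in place of a group of 11 heavy atoms (9 carbon, 2 oxygen; 2 six-membered non-aromatic rings of carbon only), on a carbonyl carbon. The incoming 1,1-dioxothian-4-yl has one six-membered non-aromatic ring with 1 hetero atom, and it has no hydrogen-bond donors, whereas the outgoing group has 1.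

Going by the values given here, no measured pair isolates this change, so any expectation rests on indirect evidence. Compound 3, which also has a non-aromatic ring with a hetero atom on the carbonyl carbon, gives 100%; 100% (2 entries). On that basis, no step beyond the scatter is expected. The estimated change is a number 4 percentage points lower from compound 2 to compound 4 (within the scatter). For compound 4, the expected value is 96%, within an estimated range of 82% to 100%.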

Compound 4, percent of the compound remaining: 93%
Compound 4: the middle estimate sits 3 percentage points above what was measured; measured number inside the range.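

In this assay, putting 1,1-dioxothian-4-yl on the carbonyl carbon, in place of the larger group with its two six-membered rings of carbon only, gives a number 7 percentage points lower from compound 2 to compound 4 (within the scatter). Going by these compounds alone, this is the first step that can be read at this place, and it shows that the read-out stays within the scatter when the hydrogen-bond donor of the outgoing group is absent and a ring with a hetero atom takes the place of the carbon-only rings. Nothing available explains this result or links it to any property of either group.

Because this single exchange alters the ring count, the hetero atom, the hydrogen-bond donors and the hydrogen-bond acceptors together, the compounds shown leave open which of these differences, if any, matters for the read-out in this assay. They also leave open how the same position would behave with a group of another kind on the carbonyl carbon, such as an amine or an open carbon chain, whether such a group would stay within the scatter of compound 2 or fall clearly away from it.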